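A few compounds are considered here, and "the series" means these few. Any claim that something is new, unique, unknown or untested is made for them only; others in the source may bear on it.

Measured so far in a functional assay on Hep 3B2 cells (Homo sapiens) for inhibition, read by sulforhodamine B assay, with a stated time of 72 h; a lower number here means a stronger inhibitor, a higher number a weaker inhibitor:
- compound 1 `CCS(=O)(=O)c1ccc(OC)c(Nc2ncc(-c3cccc(-c4cc[nH]c4)c3)o2)c1`: 2100 nM
- compound 2 `COC1=CC(=O)C(C)=C([S@@+]([O-])c2ccc(C)cc2)C1=O`: 5500 nM

Compound 2 has the higher of the two numbers at 5500 nM, which makes it the weaker inhibitor, and its gap to compound 1 lies beyond the scatter. Compound 3 `CCOC1=CC(=O)C(C)=C([S@@+]([O-])c2ccc(C)cc2)C1=O` differs from compound 2 by methyl in place of hydrogen on a saturated chain carbon bound to an oxygen on an unsaturated carbon, or methoxy to ethoxy. Among the measured compounds shown here, no measured pair shows this change, so the evidence is thin. The estimated 1.1-fold lower number from compound 2 to compound 3 (0.04 log units; within the scatter) is expected to stay within the scatter in this assay, with no firm direction. Compound 3 is expected at 5000 nM, with an estimated range from 2000 nM to 13000 nM.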

Compound 3, half-maximal inhibitory concentration: 12000 nM
For compound 3 the middle estimate is 2.4-fold (0.38 log units) below the measured one; low and high end bracket the measured number.
By their numbers in this assay, from the lowest: compound 1; then compound 2; then compound 3.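

Methoxy to ethoxy is the first one-place change in the series, and in this assay it reads as a 2.2-fold higher number from compound 2 to compound 3 (0.34 log units; beyond the scatter). The position, a saturated chain carbon bound to an oxygen on an unsaturated carbon, is therefore not neutral to an added methyl, although this rests on a single pair and the step is modest. Nothing at hand accounts for the shift.

Open, as far as these compounds go, is what a propoxy group, a longer chain or a chain ending in an amine would do at this position. Also open, from the compounds shown here alone, is whether hydroxy in place of methoxy would move the number in the opposite direction.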